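A few compounds are considered here, and "the series" means these few. Any claim that something is new, unique, unknown or untested is made for them only; others in the source may bear on it.

Working notes, tetrazole series. Compound 1 `CN(c1ccccc1CCCn1nnnc1[C@@H](COCc1ccccc1)NC(=O)C(C)(C)N)S(C)(=O)=O` gives 1720 nM in an assay on isolated protein for displacement of a labelled ligand from growth hormone secretagogue receptor type 1 (Homo sapiens), with a stated time of 1 h; on this read-out lower numbers stand for stronger inhibition and higher numbers for weaker inhibition. Compound 2 `CC(C)(N)C(=O)N[C@H](COCc1ccccc1)c1nnnn1CCCCC#N` gives 3120 nM. Compound 3 `CC(C)(N)C(=O)N[C@H](COCc1ccccc1)c1nnnn1CCC#N` gives 2940 nM; its number sits with those of compound 2 and compound 1 inside the scatter, so no ranking among the three is read. The two changes made so far at the chain on the aromatic nitrogen moved little: a 1.8-fold higher number from compound 1 to compound 2 (0.26 log units; within the scatter) and a 1.1-fold lower number from compound 2 to compound 3 (0.03 log units; within the scatter).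

Compound 4 `COC(=O)CCCn1nnnc1[C@@H](COCc1ccccc1)NC(=O)C(C)(C)N` carries (methoxycarbonyl)methyl in place of cyano on a saturated chain carbon, two bonds along the chain from an aromatic nitrogen. Both prior steps at this chain are within the scatter, so the step in this assay is expected to be a 1.0-fold lower number from compound 3 to compound 4 (0.01 log units; within the scatter), with no movement beyond scatter anticipated. Compound 4 is estimated at 2900 nM, range 1200 nM to 7000 nM.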

Compound 4, inhibition constant: 2380 nM
Beside the measured number, compound 4's estimate is 1.2-fold (0.09 log units) above it; the measured number falls inside the stated range.
By their numbers in this assay, from the lowest: compounds 1, 4, 3 and 2 (each within the scatter of the next).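

The (methoxycarbonyl)methyl group in place of cyano, on a saturated chain carbon two bonds along the chain from an aromatic nitrogen, gives a 1.2-fold lower number from compound 3 to compound 4 (0.09 log units; within the scatter) in this assay. Among these compounds, a chain ending in methoxycarbonyl, a carbonyl-bearing end not seen in the earlier compounds, therefore stays within the scatter of the nitrile chains, with a 1.3-fold lower number from compound 2 to compound 4 (0.12 log units; within the scatter), and of the sulfonamide-bearing aryl chain, with a 1.4-fold higher number from compound 1 to compound 4 (0.14 log units; within the scatter). Nothing available explains this flat response.

As far as these compounds go, whether a free carboxylic acid or an amine at the chain end would move the number beyond the scatter remains open. So does the effect of a much longer chain.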